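Moving a Methyl Group Around the Phenyl Ring

The source may hold more compounds than are shown below. What is called first, only, known or untested is meant among the compounds shown, and "the series" means these compounds.

Compound 1, `CCCc1nc(-c2ccccc2)c(CNCCN2CCN(c3ccc(C)cc3)CC2)o1`, was tested in an assay on HEK293 cells for inhibition of Voltage-dependent T-type calcium channel subunit alpha-1G (Homo sapiens), read by fluorescence, tested at 10 uM (a higher number here means more inhibition at the concentration tested (going by the name of the read-out), a lower number less inhibition), where compound 1 gives 48.1%. Going by the values given here, this is the lower of the two values measured so far. The other measured compound, compound 2, `CCCc1nc(-c2ccccc2)c(CNCCCN2CCN(c3ccc(Cl)cc3)CC2)o1`, gives 63.3% in this assay. Among the compounds with values here, compound 2 differs from compound 1 in more than one place, so the two values show only that compound 2 sits higher, by a gap beyond the usual scatter.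

Compound 3, `CCCc1nc(-c2ccccc2)c(CNCCN2CCN(c3cccc(C)c3)CC2)o1`, is not yet measured. It differs from compound 1 by 3-methylphenyl in place of 4-methylphenyl on an amine nitrogen in a ring. The same atoms are present in both, only joined differently. Within the data shown here, no measured pair shows the effect of such a change on its own. The expectation therefore rests on compound 1 alone. The step of a number 0.1 percentage points lower from compound 1 to compound 3 (within the scatter) is expected to stay within the usual scatter, with no clear direction. Compound 3 is accordingly estimated at 48%, with a range from 30% to 66%.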

Compound 3, a percentage reported as inhibition, at one concentration (the size of the read-out at that concentration, not a potency): 43.1%
Estimate against measurement, compound 3: 4.9 percentage points above; the measured number falls inside the stated range.
By their numbers in this assay, from the lowest: compounds 3 and 1 (each within the scatter of the next); then compound 2.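

Going by these compounds alone, this pair is the first in the set to differ in one place only, so it gives a direct look at a single change. In this assay, moving from 4-methylphenyl to 3-methylphenyl on the amine nitrogen in the ring comes out as a number 5 percentage points lower from compound 1 to compound 3 (within the scatter), so this assay cannot separate these two placements of the methyl group. No measurement here offers an explanation for this result.

From the compounds shown here alone, whether a different group on this phenyl ring, such as a methoxy group or a carboxylic acid in place of the methyl, would produce a step beyond the scatter remains open. Compound 2 differs from both of these compounds in more than one place, so the contributions of its chlorine and its chain cannot be told apart.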